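A few compounds are considered here, and "the series" means these few. Any claim that something is new, unique, unknown or untested is made for them only; others in the source may bear on it.

Of the compounds shown here, three built on a shared core have been tested in an assay on isolated protein with adenosine receptor A1 (Homo sapiens) as the target, tested at 10 uM; on this read-out lower numbers stand for less inhibition and higher numbers for more inhibition at the one concentration tested (going by the name of the read-out). Compound 1 `Nc1sc2c(c1C(=O)c1cccc3ccccc13)CCC2` gives 8% in this assay. Compound 2 `Nc1sc2c(c1C(=O)c1ccc(Cl)c3ccccc13)CCC2` differs from compound 1 in a single place, namely (chloro in place of hydrogen on an aromatic carbon). In this assay compound 2 gives 0%, and the step of a number 8 percentage points lower from compound 1 to compound 2 (within the scatter). Compound 3 `Nc1sc2c(c1C(=O)c1cccc3ccccc13)CCCC2` carries a different core from compound 1; the difference between the two cores is not broken down here. In this assay compound 3 gives 2%, a number close to that of compound 2 and to that of compound 1, all three lying within the scatter of one another, so none of them can be set apart from the others.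

Compound 4 `Nc1sc2c(c1C(=O)c1ccc(Cl)c3ccccc13)CCCC2` has not yet been measured in this assay. It differs from compound 3 by chloro in place of hydrogen on an aromatic carbon. The place of the change is described in exactly the same words as for the change from compound 1 to compound 2, so this is the same change, made a second time on the other core.

Among the compounds with values here, the only guide to its effect is the earlier step. Because a number 8 percentage points lower from compound 1 to compound 2 (within the scatter) stayed within the scatter, the same change is expected to leave the read-out of compound 4 in the same low region where compound 3 stands. The step that this expectation means is no change at the digits printed from compound 3 to compound 4 (within the scatter). Compound 4 is thus estimated to give 2% in this assay, with a likely range from 0% to 12%.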

Compound 4, a percentage reported as inhibition, at one concentration (the size of the read-out at that concentration, not a potency): 4.8%
Compound 4: middle estimate off by 2.8 percentage points, on the low side, and the stated range covers the measured number.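

In this assay the new step is a number 2.8 percentage points higher from compound 3 to compound 4 (within the scatter), so on this second core, too, putting chloro in place of hydrogen on an aromatic carbon does not move the reading beyond the usual scatter. Side by side, the two steps cannot be told apart, so the change behaves alike on both cores as far as this read-out can tell: the same change on two cores in this assay, a number 8 percentage points lower (within the scatter) from compound 1 to compound 2 and a number 2.8 percentage points higher (within the scatter) from compound 3 to compound 4, 10.8 percentage points apart, within the scatter of two such steps This agreement is a weak kind of transfer, however, since neither step stands out from the scatter and all four readings lie close to the bottom of the scale, so it does not show that a real effect of chloro carries from one core to the other, nor how chloro would act on a compound that inhibits strongly.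

The compounds shown leave open what a different group in that same place, such as fluoro, methoxy, an amine or a carboxylic acid, would do to the reading on either core. They also leave open whether any change to these cores can lift the reading clear of the scatter, which would give a step large enough to test properly whether it carries over.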